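Swapping a Methoxyphenyl for a Pyridyl on the Thioether Chain

A few compounds are considered here, and "the series" means these few. Any claim that something is new, unique, unknown or untested is made for them only; others in the source may bear on it.

Measured compounds:
compound 1, `COc1cccc(C(C)Sc2nc3c(cnn3C)c(=O)n2-c2ccccc2)c1`: 108 nM
compound 2, `CC(Sc1nc2c(cnn2C)c(=O)n1-c1ccc(CO)cc1)c1ccccc1`: 600 nM
compound 3, `CC(Sc1nc2nn(CC3COC3)cc2c(=O)n1-c1ccccc1)c1ccccc1`: 80 nM

All three were tested in an assay on isolated protein for inhibition of retinal dehydrogenase 2 (Homo sapiens); on this read-out lower numbers stand for stronger inhibition and higher numbers for weaker inhibition. Compound 1 gives 108 nM, the second highest of the three numbers. Its nearest neighbour is compound 3, whose 80 nM lies within the scatter of repeated measurement, so the two cannot be ordered. Compound 2, with 600 nM, stands furthest from compound 1, and that gap does lie beyond the scatter.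

The next compound, compound 4 `CC(Sc1nc2c(cnn2C)c(=O)n1-c1ccccc1)c1cccnc1`, differs from compound 1 in one place: pyridin-3-yl in place of 3-methoxyphenyl on a saturated chain carbon bound to a saturated chain carbon and a sulfur. For the measured compounds named here, no pair of measured compounds shows this particular change, since compounds 2 and 3 vary elsewhere in the molecule. In this assay a small step toward a higher number is therefore expected, one that may well stay within the scatter. Compound 4 is expected to give about 200 nM, within a range from 60 nM to 700 nM. The expected step is a 1.9-fold higher number from compound 1 to compound 4 (0.27 log units; within the scatter).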

Compound 4, half-maximal inhibitory concentration: 89 nM
The estimate for compound 4 lay 2.2-fold (0.35 log units) above the measured number, within the range that was stated.
By their numbers in this assay, from the lowest: compounds 3, 4 and 1 (each within the scatter of the next); then compound 2.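

In this assay, for the compounds shown here, the first change at this position, pyridin-3-yl in place of 3-methoxyphenyl on a saturated chain carbon bound to a saturated chain carbon and a sulfur, gives a 1.2-fold lower number from compound 1 to compound 4 (0.08 log units; within the scatter) and so cannot be told apart from no change at all. For this one pair, then, the carbon-only ring bearing its methoxy group can give way to a ring with a hetero atom without a readable loss, something compounds 2 and 3 could not show because they vary elsewhere in the molecule. Nothing available here explains this result.

On these data alone, what happens with a plain phenyl, a pyridin-4-yl or a ring carrying a carboxylic acid at this same place remains open. So does whether the pyridin-3-yl exchange would give a similar step on the other parts of the molecule varied in compounds 2 and 3.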